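Nitrophenyl in place of the hydroxyethyl-methylphenyl on the core

This account rests on a few compounds, and the source may have more. Where it says the series, first, only, none or still open, it means among the compounds named here.

For the measured compounds named here, compound 1 `Cc1cc(-c2c(O)nc3cc(Cl)c([N+](=O)[O-])cc3c2OCCC2CCCCN2)cc(C(C)O)c1` and compound 2 `O=[N+]([O-])c1cc2c(OCCC3CCCCN3)c(-c3cccc(F)c3)c(O)nc2cc1Cl` are the two measured members. Going by the values given here, in a functional assay on cells (Pituitary gland cell) for antagonist activity at Gonadotropin-releasing hormone receptor (Rattus norvegicus) (on this read-out lower numbers stand for stronger inhibition and higher numbers for weaker inhibition), compound 1 gives 63 nM and compound 2 gives 53 nM; compound 1 stands at one end of the pair, yet the only step recorded, a 1.2-fold lower number from compound 1 to compound 2 (0.08 log units; within the scatter), shows that the two are not separated beyond repeat-measurement noise.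

Compound 3 `O=[N+]([O-])c1cccc(-c2c(O)nc3cc(Cl)c([N+](=O)[O-])cc3c2OCCC2CCCCN2)c1` is not yet measured. It differs from compound 1 by 3-nitrophenyl in place of 3-(1-hydroxyethyl)-5-methylphenyl on an aromatic carbon. Among the compounds with values here, the one measured step at this carbon, a 1.2-fold lower number from compound 1 to compound 2 (0.08 log units; within the scatter), shares the leaving group but brings in 3-fluorophenyl rather than 3-nitrophenyl, so it bears on the present change only as evidence that the leaving group can be exchanged at this position without a visible shift. Within the data shown here, no step for the entering group exists. The expectation is therefore a step of a 1.1-fold lower number from compound 1 to compound 3 (0.06 log units; within the scatter), that is, nothing beyond the scatter. Compound 3 is estimated at 55 nM, with a range of 25 nM to 130 nM.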

Compound 3, half-maximal inhibitory concentration: 100 nM
The estimate for compound 3 lay 1.8-fold (0.26 log units) below the measured number, and the stated range covers the measured number.
By their numbers in this assay, from the lowest: compounds 2, 1 and 3 (each within the scatter of the next).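

In this assay, this aromatic carbon now carries a third aryl group with no separation in the read-out: a 1.6-fold higher number from compound 1 to compound 3 (0.20 log units; within the scatter), and the exchange of fluoro for nitro on the phenyl ring gives a 1.9-fold higher number from compound 2 to compound 3 (0.28 log units; within the scatter). For the compounds shown here, the second step is the first comparison that keeps the phenyl ring and changes only its substituent, and the first step shows that 3-nitrophenyl, with 0 hydrogen-bond donors, stays within the scatter of 3-(1-hydroxyethyl)-5-methylphenyl, with 1. No measurement is available to explain these results.

As far as these compounds go, it remains open whether a phenyl ring bearing an amine or a carboxylic acid at this place would separate from these three compounds. From the compounds shown here alone, the response to a longer chain in place of the 2-(piperidin-2-yl)ethoxy group is also open.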